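A few compounds are considered here, and "the series" means these few. Any claim that something is new, unique, unknown or untested is made for them only; others in the source may bear on it.

Measured compounds:
- compound 1, `COc1ccc(-c2ccc(-c3ccc(C(=N)N)cc3)s2)cc1`: 1670 nM
- compound 2, `N=C(N)c1ccc(-c2ccc(-c3cc(Cl)cc(Cl)c3)s2)cc1`: "not determined" (no result reported)

Going by the values given here, compound 1 is the only compound with a number in a functional assay on UO-31 cells (Homo sapiens) for inhibition, read by sulforhodamine B assay, with a stated time of 48 h (a higher number here means a weaker inhibitor of growth, a lower number a stronger inhibitor of growth), where compound 1 gives 1670 nM. Among the compounds with values here, compound 2 shares the same core, and in this assay compound 2 is recorded as "not determined" (no result reported), so nothing can be compared and no step between measured compounds can be drawn. Compound 3, `N=C(N)c1ccc(-c2ccc(-c3ccc(F)cc3)s2)cc1`, is not yet measured. Compound 3 differs from compound 1 in one place: fluoro in place of methoxy on an aromatic carbon. Within the data shown here, no measured pair shows what this kind of change does here, so the expectation for this assay must rest on compound 1 alone. The step from compound 1 to compound 3 is expected to be small, most likely within the usual scatter, with no firm direction, which means a step of a 1.2-fold higher number from compound 1 to compound 3 (0.08 log units; within the scatter). Compound 3 is therefore expected to give about 2000 nM in this assay, within a range of 600 nM to 6000 nM.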

Compound 3, concentration for 50% growth inhibition: 1580 nM
Compound 3: the middle estimate sits 1.3-fold (0.10 log units) above what was measured, within the range that was stated.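

In this assay, going by these compounds alone, fluoro in place of methoxy on an aromatic carbon gives a 1.1-fold lower number from compound 1 to compound 3 (0.02 log units; within the scatter), which is the first measured reading of a change at this position. In this assay, the two groups cannot be told apart here, even though the methoxy counts as a hydrogen-bond acceptor and the fluoro does not. So, for this pair, that difference in acceptor count comes with no change beyond the usual scatter, and no accompanying measurement offers an explanation for the match.

This is a single pair, so it cannot show whether the position tolerates changes in general, and compound 2 has no result to add. Going by these compounds, whether a group of a different kind on this carbon, such as an amine or a carboxylic acid, would shift the number remains open.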